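Replacing the dichlorophenoxy arm with a methoxyphenyl thioether

This account rests on a few compounds, and the source may have more. Where it says the series, first, only, none or still open, it means among the compounds named here.

Compound 1, `Nc1cc(N)c2nc(-c3ccccc3)c(Oc3ccc(Cl)c(Cl)c3)nc2c1`, carries a 3,4-dichlorophenoxy group on its core. In a functional assay on SF-268 cells (Homo sapiens) for inhibition, read by sulforhodamine B assay, with a stated time of 48 h (on this read-out higher numbers stand for weaker inhibition of growth and lower numbers for stronger inhibition of growth), compound 1 gives 52500 nM, the highest of the three numbers recorded. Compound 2, `CCOC(=O)[C@H](CCC(=O)O)NC(=O)c1ccc(Sc2nc3cc(N)cc(N)c3nc2-c2ccccc2)cc1`, gives 44700 nM in this assay, which lies within the scatter of compound 1. Compound 3, `COc1ccc(CNc2nc3cc(N)cc(N)c3nc2-c2ccccc2)cc1`, gives 21900 nM, a lower number than that of compound 1 by a margin that goes beyond the scatter.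

Compound 4 is `COc1ccc(Sc2nc3cc(N)cc(N)c3nc2-c2ccccc2)cc1`. It differs from compound 1 by (4-methoxyphenyl)sulfanyl in place of 3,4-dichlorophenoxy on an aromatic carbon. For the measured compounds named here, no measured pair isolates this change, so the expectation rests on the three numbers alone. Compound 2 and compound 3 together suggest that the core tolerates a sulfanyl or a methoxyphenyl arm without a large shift. Compound 4 is therefore expected to show a step from compound 1 of a 1.8-fold lower number from compound 1 to compound 4 (0.24 log units; within the scatter), a modest move toward a lower number that may not exceed the scatter. The estimate for compound 4 is 30000 nM, with a range from 12000 nM to 75000 nM.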

Compound 4, concentration for total growth inhibition: < 100000 nM
Compound 4: only a limit was reported; the forecaster's own chance of this, stated with the estimate: 10%; the middle value does not contradict the limit.
By their numbers in this assay, from the lowest: compound 3; then compounds 2 and 1 (each within the scatter of the next).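

In this assay compound 4 is reported only as a limit, < 100000 nM. For the compounds shown here, no step from compound 1 to compound 4 can therefore be read. The compounds shown leave open whether (4-methoxyphenyl)sulfanyl in place of 3,4-dichlorophenoxy changes growth inhibition at all, and in which direction.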